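A few compounds are considered here, and "the series" means these few. Any claim that something is new, unique, unknown or untested is made for them only; others in the source may bear on it.

Measured so far in an assay on isolated protein for inhibition of Amine oxidase [flavin-containing] B (Homo sapiens); a lower number here means a stronger inhibitor, a higher number a weaker inhibitor:
compound 1 `C#CCNC1CCc2c(SCCc3cccc(C)c3)cccc21` gives 0.35 nM
compound 2 `C#CCNC1CCc2c(SCc3ccc(Br)cc3)cccc21` gives 1310 nM
compound 3 `C#CCNC1CCc2c(SCc3ccc(Cl)c(Cl)c3)cccc21` gives 2840 nM

Compound 1 has the lowest half-maximal inhibitory concentration of the three; the gap to compound 2 and the larger gap to compound 3 both lie well beyond the scatter. Compounds 2 and 3 carry halogenated phenyl rings, but they also differ from compound 1 in the length of the chain between the sulfur and the aryl ring, so their weaker values cannot be assigned to the halogens alone. For the measured compounds named here, no single-change step between measured compounds is available.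

Compound 4 `C#CCNC1CCc2c(SCCc3ccc(F)c(F)c3)cccc21` keeps the shared core and the chain of compound 1 and changes only the terminal ring: 3,4-difluorophenyl in place of 3-methylphenyl on a saturated chain carbon, two bonds along the chain from a sulfur. Going by the values given here, with no measured pair isolating a ring swap on this chain, the expectation rests on compound 1 alone. A small loss is expected, from compound 1 to compound 4 in this assay a 4.3-fold higher number from compound 1 to compound 4 (0.63 log units; beyond the scatter), since the only halogenated rings in the set, on compounds 2 and 3, sit on a different chain and give no clean guide. Compound 4 is estimated at 1.5 nM, within 0.3 nM to 10 nM.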

Compound 4, half-maximal inhibitory concentration: 3240 nM
Estimate against measurement, compound 4: 2200-fold (3.33 log units) below; measured number outside the range, above it.
By their numbers in this assay, from the lowest: compound 1; then compound 2; then compounds 3 and 4 (each within the scatter of the next).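

In this assay the terminal ring on this chain proves highly sensitive: 3,4-difluorophenyl in place of 3-methylphenyl on a saturated chain carbon, two bonds along the chain from a sulfur, gives a large step (a 9300-fold higher number from compound 1 to compound 4 (3.97 log units; beyond the scatter)) that lies beyond the scatter. For the compounds shown here, this is the first single-change step, and it shows that with the chain held constant, the swap of the terminal ring alone can shift the number by a large step, something compounds 2 and 3 could not show. No measurement available accounts for the size of this step.

Still open, on these data alone, is which part of the change carries the loss: the departure of the 3-methyl group, or the arrival of one or both fluorines, a question that unsubstituted phenyl, 3-fluorophenyl or 4-fluorophenyl on this same chain would separate. Also open, as far as these compounds go, is how much of the weak numbers of compounds 2 and 3 belongs to their shorter chain rather than their rings, which 4-bromophenyl or 3,4-dichlorophenyl on the chain of compound 1 would settle.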